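The source may hold more compounds than are shown below. What is called first, only, known or untested is meant among the compounds shown, and "the series" means these compounds.

Measured compounds:
- compound 1, `Cc1ccc2oc(=O)c(-c3ccc(Br)nn3)cc2c1`: 2160 nM
- compound 2, `COc1ccc2oc(=O)c(-c3ccc(Br)nn3)cc2c1`: 560 nM
- compound 3, `Cc1ccc2cc(-c3ccc(Cl)nn3)c(=O)oc2c1`: 2510 nM

All three values come from an assay on cells for inhibition of Amine oxidase [flavin-containing] B (Homo sapiens), read by fluorescence and Amplex Red, with a stated time of 15 min; a lower number here means a stronger inhibitor, a higher number a weaker inhibitor. Compound 1 and compound 2 share a core and differ only by methoxy in place of methyl on an aromatic carbon. That change gives a 3.9-fold lower number from compound 1 to compound 2 (0.59 log units; beyond the scatter). Compound 3 sits on a different core; the difference between the core of compound 3 and the core of compound 1 is not broken down here. Compound 3 gives 2510 nM in this assay, which against compound 1 lies within the scatter, while against compound 2 the gap is beyond the scatter.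

Compound 4, `COc1ccc2cc(-c3ccc(Cl)nn3)c(=O)oc2c1`, has not been measured. It differs from compound 3 by methoxy in place of methyl on an aromatic carbon, the same change as from compound 1 to compound 2, at a place described in the same words. Among the measured compounds shown here, the expectation for compound 4 rests on that one earlier step, because a 3.9-fold lower number from compound 1 to compound 2 (0.59 log units; beyond the scatter) is the only instance of this change measured here, and on a single core. Compound 4 is therefore expected to give about 700 nM in this assay, within roughly 300 nM to 1600 nM. That estimate means a step of a 3.6-fold lower number from compound 3 to compound 4 (0.55 log units; beyond the scatter), expected to be of similar size to the earlier one.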

Compound 4, half-maximal inhibitory concentration: 19200 nM
Compound 4: the middle estimate sits 27-fold (1.44 log units) below what was measured; measured number above the stated range.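

On the core of compound 3, methoxy in place of methyl on an aromatic carbon gives a 7.6-fold higher number from compound 3 to compound 4 (0.88 log units; beyond the scatter) and so does not repeat in this assay what it did on the core of compound 1. Set side by side, the two steps run in opposite directions, and the gap between them is larger than scatter would account for: the same change on two cores in this assay, a 3.9-fold lower number (0.59 log units; beyond the scatter) from compound 1 to compound 2 and a 7.6-fold higher number (0.88 log units; beyond the scatter) from compound 3 to compound 4, 30-fold (1.47 log units) apart, beyond the scatter of two such steps

The outcome of this change therefore depends on the core across these two pairs, but two pairs do not show which difference between the cores matters, nor how the change would behave on a further core.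

No pair shown separates the differences between the core of compound 1 and the core of compound 3, so the source of the reversal remains open. Also open, as far as these compounds go, is how an ethoxy, a hydroxyl or an amine on the same aromatic carbon would behave on either core.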